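The compounds below may be only part of what the source reports. "The series", "measured", "known", "first", "only" and "open" are said of these compounds alone.

Compound 1 `Fc1ccc(-c2cc(OC[C@@H]3CCN3)cnc2Cl)cn1` gives 0.0049 nM in an assay on membranes from brain with Neuronal acetylcholine receptor; alpha4/beta2 (Rattus norvegicus) as the target (on this read-out higher numbers stand for weaker inhibition and lower numbers for stronger inhibition), and compound 2 `Fc1ccc(-c2cc(OC[C@@H]3CCCN3)cnc2Cl)cn1` gives 0.0179 nM. The two differ by one change, (pyrrolidin-2-yl in place of azetidin-2-yl on a saturated chain carbon bound to an oxygen on an aromatic ring), and that change produced a 3.7-fold higher number from compound 1 to compound 2 (0.56 log units; beyond the scatter). Compound 3 `Fc1cc(/C=C/c2cc(OC[C@@H]3CCN3)cnc2Cl)ccn1` has a different core; how it differs from the core of compound 1 is not broken down here. In this assay compound 3 gives 0.0031 nM, and against compound 1 the two numbers lie within the scatter. Compound 4 `Fc1cc(/C=C/c2cc(OC[C@@H]3CCCN3)cnc2Cl)ccn1` is not yet measured; it differs from compound 3 by pyrrolidin-2-yl in place of azetidin-2-yl on a saturated chain carbon bound to an oxygen on an aromatic ring, the same change as that from compound 1 to compound 2. Because that earlier step gave a 3.7-fold higher number from compound 1 to compound 2 (0.56 log units; beyond the scatter), a step of similar size is expected here, namely a 3.7-fold higher number from compound 3 to compound 4 (0.57 log units; beyond the scatter). Compound 4 is therefore estimated at 0.0115 nM, with a range from 0.005 nM to 0.03 nM.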

Compound 4, inhibition constant: 0.0094 nM
Compound 4: the middle estimate sits 1.2-fold (0.09 log units) above what was measured, within the range that was stated.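

Replacing azetidin-2-yl with pyrrolidin-2-yl on the core of compound 3 gave a 3.0-fold higher number from compound 3 to compound 4 (0.48 log units; beyond the scatter) in this assay. On the two cores, the change came with a step of much the same size: the same change on two cores in this assay, a 3.7-fold higher number (0.56 log units; beyond the scatter) from compound 1 to compound 2 and a 3.0-fold higher number (0.48 log units; beyond the scatter) from compound 3 to compound 4, 1.2-fold (0.08 log units) apart, within the scatter of two such steps. Within the data shown here, this rests on only two matched pairs in one assay; it shows that the step carried over between these two cores, but not that it would hold on any other core or in any other assay.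

The compounds shown leave open how a piperidin-2-yl group would compare in the same place, on a saturated chain carbon bound to an oxygen on an aromatic ring. They also leave open whether a methyl group on the nitrogen of either ring would alter the step.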